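Amino for Methoxy on a Shared Core at the Limit

A few compounds are considered here, and "the series" means these few. Any claim that something is new, unique, unknown or untested is made for them only; others in the source may bear on it.

Three compounds share a core and differ only in the group on one aromatic carbon: compound 1 `C#Cc1cn([C@@H]2O[C@H](CO)[C@@H](O)[C@H]2O)c2nc(N)nc(OC)c12` carries ethynyl, compound 2 `COc1nc(N)nc2c1c(-c1ccoc1)cn2[C@@H]1O[C@H](CO)[C@@H](O)[C@H]1O` furan-3-yl, and compound 3 `COc1nc(N)nc2c1c(-c1ccco1)cn2[C@@H]1O[C@H](CO)[C@@H](O)[C@H]1O` furan-2-yl. In a functional assay on HL-60 cells (Homo sapiens) for antiproliferative activity, read by XTT assay, with a stated time of 72 h (on this read-out lower numbers stand for stronger inhibition and higher numbers for weaker inhibition), compound 1 gives only a limit, > 20000 nM. In this assay compound 2 likewise gives only a limit, > 20000 nM. Compound 3 also stops at a limit, > 20000 nM. The steps a step that the two limits leave unreadable from compound 1 to compound 2, a step that the two limits leave unreadable from compound 1 to compound 3 and a step that the two limits leave unreadable from compound 2 to compound 3 therefore say nothing about size or direction, since (the limit of > 20000 nM in this assay, at which 3 of the 3 values shown sit).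

Compound 4 `Nc1nc(N)c2c(-c3ccoc3)cn([C@@H]3O[C@H](CO)[C@@H](O)[C@H]3O)c2n1` keeps the furan-3-yl of compound 2 and changes one group: amino in place of methoxy on an aromatic carbon. For the measured compounds named here, no measured step touches this position, so none of the measured steps bears on the change, and the only guide is where compound 2 stands, at a limit. Compound 4 is therefore expected to remain near or beyond that limit, with a step that the limit leaves unreadable from compound 2 to compound 4 as the step implied by the estimate. The value of compound 4 in this assay is estimated at 30000 nM, within 6000 nM to 150000 nM.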

Compound 4, half-maximal inhibitory concentration: > 20000 nM
Compound 4 gave a limit, no number; the forecaster's own chance of this, stated with the estimate: 75%; the middle value is on the limit's open side.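

Compound 4, like compound 2, stops at a limit in this assay, so no step can be read between compound 2 and compound 4: the limit of > 20000 nM in this assay, at which 4 of the 4 values shown sit. The compounds shown leave open whether amino in place of methoxy, or any of the three groups compared, changes the activity at all.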